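The source may hold more compounds than are shown below. What is called first, only, known or untested is meant among the compounds shown, and "the series" means these compounds.

Measured so far:
Compound 1, `CC(C)=CCC[C@@](C)(/C=C/c1ccccc1)/C=C/c1ccc(O)cc1`. In a functional assay on NALM-6 cells (Homo sapiens) for cytotoxicity, with a stated time of 72 h (on this read-out higher numbers stand for an effect only at larger amounts of compound and lower numbers for an effect already at smaller amounts), compound 1 gives > 43400 nM, a limit of the assay and not a number.
Compound 2, `CC(C)=CCC[C@](C)(/C=C/c1ccc(O)cc1)/C=C/c1cccc(F)c1`. In this assay compound 2 gives > 43400 nM, again a limit.
Compound 3, `C=C[C@@](C)(/C=C/c1ccc(Nc2ccc(F)cc2)cc1)CCC=C(C)C`. In this assay compound 3 gives > 43400 nM, also a limit.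

The change from compound 1 to compound 2 is fluoro in place of hydrogen on an aromatic carbon. The step it made, a step that the two limits leave unreadable from compound 1 to compound 2, cannot be read, owing to the limit of > 43400 nM in this assay, at which 3 of the 3 values shown sit. The cores of compound 1 and compound 3 differ by more than one place; that difference is not broken down here.

Compound 4, `C=C[C@@](C)(/C=C/c1ccc(Nc2ccc(F)c(F)c2)cc1)CCC=C(C)C`, is not yet measured. It differs from compound 3 by fluoro in place of hydrogen on an aromatic carbon. This is the same kind of change as from compound 1 to compound 2, but the place is not the same: in compound 4 the entering fluoro sits ortho to a fluoro group and meta to a large group, whereas in compound 2 it sits meta to a large group only. With every value shown sitting at the limit of > 43400 nM in this assay, at which 3 of the 3 values shown sit, the step expected from compound 3 to compound 4 is a step that the limit leaves unreadable from compound 3 to compound 4, and a limit rather than a number is the likeliest outcome. For compound 4 the estimate in this assay is 60000 nM, between 15000 nM and 250000 nM.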

Compound 4, half-maximal effective concentration: > 43400 nM
Compound 4 gave a limit, no number; the forecaster's own chance of this, stated with the estimate: 80%; the middle value is on the limit's open side.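

In this assay compound 4 gives > 43400 nM as a limit and not a number. No step can be read from compound 3 to compound 4, nor between compound 1 and compound 2: the limit of > 43400 nM in this assay, at which 4 of the 4 values shown sit. The compounds shown leave open what fluoro in place of hydrogen does on this read-out, and which change to the shared core would give a readable value.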